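Benzyl replacement in the piperidinol amine series

This account rests on a few compounds, and the source may have more. Where it says the series, first, only, none or still open, it means among the compounds named here.

Working notes on a series measured in an assay on Sf21 cells for inhibition of ubiquitin carboxyl-terminal hydrolase 7 (Homo sapiens), read by spectrophotometry, with stated times of 30 min and 2 h; on this read-out lower numbers stand for stronger inhibition and higher numbers for weaker inhibition. Compound 1 `O=c1c2cnn(-c3ccc(F)cc3)c2ncn1CC1(O)CCN(Cc2ccc(Cl)cc2Cl)CC1` gives 3300 nM in this assay. Within the data shown here, compound 2 `O=c1c2cnn(-c3ccc(F)cc3)c2ncn1CC1(O)CCN(Cc2ccc(Br)cc2Cl)CC1` gives 1900 nM in this assay, the lowest of the two numbers so far, with compound 1 as its nearest neighbour. Among the measured compounds shown here, the only step measured is a 1.7-fold lower number from compound 1 to compound 2 (0.24 log units; within the scatter), a halogen exchange on the benzyl ring.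

Compound 3 `COC(=O)c1ccc(CN2CCC(O)(Cn3cnc4c(cnn4-c4ccc(F)cc4)c3=O)CC2)c(F)c1` is not yet measured. It differs from compound 2 by 2-fluoro-4-(methoxycarbonyl)phenyl in place of 4-bromo-2-chlorophenyl on a saturated chain carbon bound to an amine nitrogen in a ring. For the measured compounds named here, no measured step exchanges halogens for an ester on this ring, so the single step from compound 1 to compound 2 bears only loosely on the change; it shows that one substituent swap on this ring left the number within the scatter. On that slender basis a step of a 1.6-fold higher number from compound 2 to compound 3 (0.20 log units; within the scatter) is expected for compound 3, with wide uncertainty. The estimate for compound 3 in this assay is 3000 nM, with a range from 700 nM to 13000 nM.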

Compound 3, half-maximal inhibitory concentration: 800 nM
Compound 3: the middle estimate sits 3.8-fold (0.57 log units) above what was measured; measured number inside the range.
By their numbers in this assay, from the lowest: compound 3; then compounds 2 and 1 (each within the scatter of the next).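

Unlike the halogen exchange, replacing the halogenated ring with 2-fluoro-4-(methoxycarbonyl)phenyl moves the number in this assay beyond the scatter, with a 2.4-fold lower number from compound 2 to compound 3 (0.38 log units; beyond the scatter) and a 4.1-fold lower number from compound 1 to compound 3 (0.62 log units; beyond the scatter). The group on the saturated chain carbon bound to an amine nitrogen in a ring can therefore change the number measurably, and this position accepts an ester-bearing ring with 2 hydrogen-bond acceptors in place of a ring with 0, with no loss in this assay. No measured evidence bears on why the number falls.

The compounds shown do not separate the contribution of the fluorine from that of the methoxycarbonyl group, since both enter together as the bromine or chlorines leave. Also open, going by these compounds, is how a carboxylic acid, a primary amide or a nitrile in place of the methoxycarbonyl group would read.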